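The source may report more compounds than this note shows. Statements on the series, on what has been measured and on what is new or still open speak of the compounds shown alone.

Series notes. The shared core is carried unchanged through the set; only the substituent on the six-membered aromatic ring changes. Compound 1 `COCc1ccccc1C1Cc2nccn2C1` and compound 2 `c1ccc(C2Cc3nccn3C2)cc1` have been measured in a functional assay on CHO cells for agonist activity at Alpha-1D adrenergic receptor (Homo sapiens), read by FLIPR and calcium flux; on this read-out higher numbers stand for an effect only at larger amounts of compound and lower numbers for an effect already at smaller amounts; compound 3 `FC(F)Oc1ccccc1C1Cc2nccn2C1` has no result there, and compound 4 `N#Cc1ccccc1C1Cc2nccn2C1` is still to be measured.

For compound 1 the result in this assay is a limit of the assay, > 10000 nM. Compound 2 has several entries in this assay, > 10000 nM; 7360 nM; > 10000 nM; > 10000 nM (4 entries); these repeated entries the several entries of compound 2 in this assay, > 10000 nM; 7360 nM; > 10000 nM; > 10000 nM (4 entries) are the only repeat in the set. For compound 3 the entry in this assay reads "not determined" (no result reported), so compound 3 stands nowhere on the numbers shown. Beside it sit the limit of > 10000 nM in this assay, at which 1 of the 3 values shown sits, and one further entry without a single number, and no step between measured compounds can be drawn from it.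

The change to compound 4 is cyano in place of difluoromethoxy on an aromatic carbon, in words cyano in place of difluoromethoxy on an aromatic carbon. For the measured compounds named here, no measured step exists in the set, so no step in this assay beyond the scatter is expected in either direction. Compound 4 is expected to sit at the limit as well. The estimate for compound 4 in this assay is 15000 nM, with a range from 3000 nM to 60000 nM.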

Compound 4, half-maximal effective concentration: > 10000 nM
Compound 4 ended at the assay's limit; the forecaster's own chance of this, stated with the estimate: 80%; the middle value lies beyond the limit too.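

In this assay compound 1 and compound 4 both stand at a limit of the assay, and no new step can be read between them. The compounds shown leave open whether the cyano group of compound 4 and the methoxymethyl group of compound 1 differ at all on this read-out.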